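Replacing the substituted ring with plain phenyl on the carbonyl carbon

This account rests on a few compounds, and the source may have more. Where it says the series, first, only, none or still open, it means among the compounds named here.

Compound 2 `COc1c(Br)cccc1C(=O)Nc1ccc(Sc2nc3ccccc3s2)c(Cl)c1` is one of two measured compounds that differ only in the group attached to the carbonyl carbon. In an assay for inhibition of HSP60/HSP10 (Homo sapiens), with a stated time of 60 min (a lower number here means a stronger inhibitor, a higher number a weaker inhibitor), compound 2 gives > 100000 nM, which is a limit of the assay and not a measured number. Its partner, compound 1 `O=C(Nc1ccc(Sc2nc3ccccc3s2)c(Cl)c1)c1cc(Br)cc(Br)c1`, in this assay gives > 100000 nM, again a limit rather than a number. The step that the two limits leave unreadable from compound 1 to compound 2 therefore cannot be read in size or direction; what both values share is the limit of > 100000 nM in this assay, at which 2 of the 2 values shown sit. Compound 3 `O=C(Nc1ccc(Sc2nc3ccccc3s2)c(Cl)c1)c1ccccc1` makes the next change: a group of 6 heavy atoms (6 carbon; one six-membered aromatic ring of carbon only) in place of a group of 9 heavy atoms (7 carbon, 1 oxygen, 1 bromine; one six-membered aromatic ring of carbon only), on a carbonyl carbon. Going by the values given here, no measured step bears on this change with a readable size, so the data give no direction to expect. Compound 3 is therefore expected to sit near the same limit, with an estimated value of 150000 nM ranging from 30000 nM to 600000 nM. The step that the limit leaves unreadable from compound 2 to compound 3 is expected to be none beyond the scatter.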

Compound 3, half-maximal inhibitory concentration: > 100000 nM
Compound 3: only a limit was reported (the forecaster's own chance of this, stated with the estimate: 75%); the middle value is on the limit's open side.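

Compound 3 in this assay gives > 100000 nM, a limit and not a number. No step among compound 1, compound 2 and compound 3 can be read, as all three share one limit: the limit of > 100000 nM in this assay, at which 3 of the 3 values shown sit.

Going by these compounds, whether any group on the carbonyl carbon would give a readable value in this assay remains open.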